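Three close neighbours and a trichlorinated newcomer

The source may report more compounds than this note shows. Statements on the series, on what has been measured and on what is new or still open speak of the compounds shown alone.

Measured in a functional assay on A549 cells (Homo sapiens) for antiproliferative activity, read by MTT assay, with a stated time of 72 h; a higher number here means a weaker inhibitor, a lower number a stronger inhibitor:
Compound 1 `NC1=NC2(CCOCC2)N(OCCCOc2ccccc2)C(N)=N1` gives 1080 nM
Compound 2 `COc1ccc(OCCCON2C(N)=NC(N)=NC23CCOCC3)cc1` gives 660 nM
Compound 3 `NC1=NC2(CCOCC2)N(OCCCOc2ccc(F)cc2)C(N)=N1` gives 1060 nM

Compound 3 has no clear place in the order, since a 1.0-fold lower number from compound 1 to compound 3 (0.01 log units; within the scatter) and a 1.6-fold higher number from compound 2 to compound 3 (0.21 log units; within the scatter) both stay inside the scatter. Compound 4 `NC1=NC2(CCOCC2)N(OCCCOc2cc(Cl)c(Cl)cc2Cl)C(N)=N1` is still unmeasured. It carries 2,4,5-trichlorophenyl in place of 4-fluorophenyl on an oxygen on a saturated carbon. Earlier swaps on an aromatic carbon moved little, with a 1.6-fold lower number from compound 1 to compound 2 (0.21 log units; within the scatter) for methoxy and a 1.0-fold lower number from compound 1 to compound 3 (0.01 log units; within the scatter) for fluoro, both within the scatter. Among the compounds with values here, no measured compound carries chlorine, so these steps guide only loosely. In this assay the expected change stays within the scatter, leaning weakly towards a lower number. The estimated step is a 1.8-fold lower number from compound 3 to compound 4 (0.25 log units; within the scatter) in this reading. The estimate for compound 4 is 600 nM within a range from 180 nM to 1700 nM.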

Compound 4, half-maximal inhibitory concentration: 680 nM
The estimate for compound 4 lay 1.1-fold (0.05 log units) below the measured number; low and high end bracket the measured number.
By their numbers in this assay, from the lowest: compounds 2, 4, 3 and 1 (each within the scatter of the next).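

In this assay, the group on this oxygen can change from a ring with one substituent or none to 2,4,5-trichlorophenyl with every step staying within the scatter (a 1.6-fold lower number from compound 3 to compound 4 (0.19 log units; within the scatter); a 1.0-fold higher number from compound 2 to compound 4 (0.01 log units; within the scatter); a 1.6-fold lower number from compound 1 to compound 4 (0.20 log units; within the scatter)). Three chlorines on the ring therefore do not separate compound 4 from compound 1, compound 2 or compound 3. Nothing measured here explains this closeness. Still open, on these data alone, is whether an amine or a carboxylic acid on the aromatic ring, or a longer chain in place of the present one, would move the number beyond the scatter.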